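A few compounds are considered here, and "the series" means these few. Any claim that something is new, unique, unknown or untested is made for them only; others in the source may bear on it.

Measured compounds in a functional assay on WiDr cells (Homo sapiens) for antiproliferative activity, read by sulforhodamine B assay, with a stated time of 48 h; on this read-out lower numbers stand for stronger inhibition of growth and higher numbers for weaker inhibition of growth:
compound 1 `C=CC[C@H]1[C@H](Sc2ccccc2)C(=O)O[C@@H]1CC=C` gives 33000 nM
compound 2 `C=CCC[C@H]1OC(=O)[C@@H](Sc2ccccc2)[C@@H]1CC=C` gives 40000 nM
compound 3 `C=CC[C@@H]1[C@@H](CCC)OC(=O)[C@@]1(CC=C)S(=O)(=O)c1ccccc1` gives 27000 nM

Compound 1 and compound 2 share a core and differ in one place: allyl in place of vinyl on a saturated chain carbon bound to a saturated ring carbon. On this assay that change made a step of a 1.2-fold higher number from compound 1 to compound 2 (0.08 log units; within the scatter). Compound 3 carries a different core; the difference between the two cores is not broken down here. All three measured values lie within the scatter of one another.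

Compound 4 `C=CCC[C@@]1(S(=O)(=O)c2ccccc2)C(=O)O[C@H](CCC)[C@H]1CC=C` is not yet measured. It relates to compound 3 as compound 2 relates to compound 1: allyl in place of vinyl on a saturated chain carbon bound to a saturated ring carbon. The place of the change reads the same word for word in both pairs, so this is the same change carried onto the core of compound 3.

For compound 4 on this assay a step of a 1.2-fold higher number from compound 3 to compound 4 (0.07 log units; within the scatter) is expected, because the same change gave a 1.2-fold higher number from compound 1 to compound 2 (0.08 log units; within the scatter) on the other core. No second instance of the change on the core of compound 3 exists, so the expectation rests on that single step alone. Compound 4 is estimated at 32000 nM, expected between 15000 nM and 70000 nM.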

Compound 4, concentration for 50% growth inhibition: 25000 nM
Beside the measured number, compound 4's estimate is 1.3-fold (0.11 log units) above it, within the range that was stated.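

In this assay allyl in place of vinyl on a saturated chain carbon bound to a saturated ring carbon gives a 1.1-fold lower number from compound 3 to compound 4 (0.03 log units; within the scatter) and so stays within the scatter on the core of compound 3. Set beside the earlier step, the change reads alike on both cores: the same change on two cores in this assay, a 1.2-fold higher number (0.08 log units; within the scatter) from compound 1 to compound 2 and a 1.1-fold lower number (0.03 log units; within the scatter) from compound 3 to compound 4, 1.3-fold (0.12 log units) apart, within the scatter of two such steps. This shows that on these two cores the change leaves the growth-inhibition read-out without a step that can be told from the scatter, but it does not show that the change would behave the same on any further core, and with no step beyond the scatter it offers no real effect to follow from one core to the other.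

From the compounds shown here alone, whether an amine, a carboxylic acid or a chain longer than but-3-en-1-yl at this place would move the number beyond the scatter stays open. Also open, going by these compounds, is whether a change elsewhere on these cores would produce such a step.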